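The source may report more compounds than this note shows. Statements on the series, on what has been measured and on what is new or still open speak of the compounds shown alone.

Compound 1, `Nc1cccc(/C=C2\SC(=O)N(Cc3ccc(F)cc3)C2=O)c1`, is the starting point of this set. In a functional assay on HeLa cells (Homo sapiens) for cytotoxicity, read by cell counting, with a stated time of 4 days (on this read-out higher numbers stand for weaker inhibition and lower numbers for stronger inhibition), compound 1 gives 86000 nM. Compound 2, `Nc1cccc(/C=C2\SC(=O)N(Cc3cccc(Cl)c3)C2=O)c1`, differs from it by 3-chlorophenyl in place of 4-fluorophenyl on a saturated chain carbon bound to an amide-type nitrogen in a ring. In this assay compound 2 gives 250000 nM, the step being a 2.9-fold higher number from compound 1 to compound 2 (0.46 log units; beyond the scatter). Compound 3, `C=C(Br)C(=O)Nc1ccc(/C=C2\SC(=O)N(Cc3ccc(F)cc3)C2=O)cc1`, is built on a different core; the difference between its core and the core of compound 1 is not broken down here. In this assay compound 3 gives 2000 nM, the lowest of the three numbers, and its gaps to compound 1 and to compound 2 both lie beyond the scatter. Compound 4, `C=C(Br)C(=O)Nc1ccc(/C=C2\SC(=O)N(Cc3cccc(Cl)c3)C2=O)cc1`, is not yet measured. It differs from compound 3 by 3-chlorophenyl in place of 4-fluorophenyl on a saturated chain carbon bound to an amide-type nitrogen in a ring, the same change, in the same place, that separates compound 1 from compound 2. In this assay the expected step is a 2.3-fold higher number from compound 3 to compound 4 (0.35 log units; beyond the scatter), a weakening of roughly the size seen once before, a 2.9-fold higher number from compound 1 to compound 2 (0.46 log units; beyond the scatter), with the range widened as that earlier instance sits on a different core and stands alone. Compound 4 is therefore expected to give 4500 nM, between 1500 nM and 14000 nM.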

Compound 4, half-maximal inhibitory concentration: 8900 nM
Compound 4: the middle estimate sits 2.0-fold (0.30 log units) below what was measured, within the range that was stated.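

In this assay, replacing 4-fluorophenyl with 3-chlorophenyl again gives a higher number, a 4.5-fold higher number from compound 3 to compound 4 (0.65 log units; beyond the scatter), so the direction seen on the earlier core holds on this one. Within the resolution of these measurements, the size of the step also carries over: the same change on two cores in this assay, a 2.9-fold higher number (0.46 log units; beyond the scatter) from compound 1 to compound 2 and a 4.5-fold higher number (0.65 log units; beyond the scatter) from compound 3 to compound 4, 1.5-fold (0.18 log units) apart, within the scatter of two such steps. Within the data shown here, this rests on just two pairs in one cell assay, so it shows only that the change behaved alike on these two cores, not that it would do so on any other core, and it does not explain why either step has the size it does.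

The change alters both the halogen and its place on the aromatic ring at once, and the compounds shown do not separate these two contributions. Also open, as far as these compounds go, is how an unsubstituted phenyl, a pyridine or a longer chain would compare with these groups on a saturated chain carbon bound to an amide-type nitrogen in a ring.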